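Swapping the indole for a pyridine on the shared core

The compounds below may be only part of what the source reports. "The series", "measured", "known", "first", "only" and "open" are said of these compounds alone.

Of the compounds shown here, three built on one shared core have been measured in a functional assay on K562 cells (Homo sapiens) for inhibition, read by trypan blue exclusion, with a stated time of 72 h; on this read-out lower numbers stand for stronger inhibition and higher numbers for weaker inhibition. Compound 1 `Cn1c(=O)c(S(=O)(=O)c2ccc(F)cc2F)cc2cnc(Nc3cccc4[nH]ccc34)nc21` gives 1500 nM and stands second highest of the three numbers. Its nearest neighbour is compound 2 `Cn1c(=O)c(S(=O)(=O)c2ccc(F)cc2)cc2cnc(Nc3cccc4[nH]ccc34)nc21`, which gives 750 nM; the furthest is compound 3 `Cc1ccc(S(=O)(=O)c2cc3cnc(Nc4cnc5[nH]ccc5c4)nc3n(C)c2=O)cc1`, which gives 15000 nM. Among the measured compounds shown here, the only step between two compounds differing in one place is a 2.0-fold lower number from compound 1 to compound 2 (0.30 log units; within the scatter), which came from hydrogen in place of fluoro on an aromatic carbon and stays within the scatter.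

Compound 4 `Cn1c(=O)c(S(=O)(=O)c2ccc(F)cc2F)cc2cnc(Nc3ccccn3)nc21` has not yet been measured in this assay. It differs from compound 1 in one place: pyridin-2-yl in place of 1H-indol-4-yl on a nitrogen on an aromatic ring. The group that leaves carries one hydrogen-bond donor; the group that enters carries none and brings one hydrogen-bond acceptor. For the measured compounds named here, no measured step touches this position. The step from compound 1 to compound 2 concerns another part of the molecule and cannot guide this change. Compound 3 differs from compound 1 in two places at once, so only its two values can be set side by side, and they allow no single-change reading. Going by the values given here, with no precedent, the step from compound 1 to compound 4 is expected to be a 2.7-fold higher number from compound 1 to compound 4 (0.43 log units; beyond the scatter), towards a weaker result. Compound 4 is therefore estimated at 4000 nM, in a range from 1000 nM to 16000 nM.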

Compound 4, half-maximal inhibitory concentration: 35000 nM
Compound 4: middle estimate off by 8.8-fold (0.94 log units), on the low side, and the stated range ends below it.
By their numbers in this assay, from the lowest: compounds 2 and 1 (each within the scatter of the next); then compound 3; then compound 4.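

Among the compounds shown here, replacing 1H-indol-4-yl with pyridin-2-yl on this nitrogen gives a 23-fold higher number from compound 1 to compound 4 (1.37 log units; beyond the scatter) in this assay, which shows that this position is sensitive to change, whereas the one earlier single change, elsewhere on the molecule, gave a 2.0-fold lower number from compound 1 to compound 2 (0.30 log units; within the scatter). Several things change together in this one swap: the entering group has fewer heavy atoms, a single six-membered ring in place of the five-membered and six-membered rings of the leaving group, no hydrogen-bond donor, and a hydrogen-bond acceptor that the leaving group lacks. Nothing measured here accounts for the size of this step.

The compounds shown leave open which of these differences matters most: a plain phenyl group on the same nitrogen would separate the effect of the pyridine ring nitrogen from that of losing the five-membered ring, and a 3-aminophenyl group would show what a hydrogen-bond donor on a single ring can do. Also open, as far as these compounds go, is whether pyridin-2-yl has the same effect when hydrogen stands in place of fluoro, as in compound 2.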